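Chloro for Methyl: Expecting Compound 3

The source may report more compounds than this note shows. Statements on the series, on what has been measured and on what is new or still open speak of the compounds shown alone.

Compound 1 `C#CCNC1CCc2c(SCc3cccc(C)c3)cccc21` — > 100000 nM
Compound 2 `C#CCNC1CCc2c(SCCc3ccc(C)cc3)cccc21` — 4520 nM

In an ADME assay on isolated protein for inhibition of Amine oxidase [flavin-containing] B (Homo sapiens) (on this read-out higher numbers stand for weaker inhibition and lower numbers for stronger inhibition), compound 1 gives only a limit of the assay, > 100000 nM, as shown by the limit of > 100000 nM in this assay, at which 1 of the 2 values shown sits. Compound 2 gives a number, 4520 nM. Compound 3, `C#CCNC1CCc2c(SCc3cccc(Cl)c3)cccc21`, differs from compound 1 by chloro in place of methyl on an aromatic carbon. Within the data shown here, no measured pair shows such a swap, and compound 1 offers no number to start from, so the move from compound 1 to compound 3 is expected to stay within the scatter, a step that the limit leaves unreadable from compound 1 to compound 3. Compound 3 is estimated at 150000 nM, between 30000 nM and 1000000 nM, most likely again a limit.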

Compound 3, half-maximal inhibitory concentration: 1090 nM
Compound 3: middle estimate off by 140-fold (2.14 log units), on the high side; measured number below the stated range.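

The position held by methyl in compound 1 responds strongly to what sits there: in this assay, chloro in place of methyl gives an at least 91-fold lower number from compound 1 to compound 3 (1.96 log units; beyond the scatter). Only one heavy atom is exchanged, with no change in rings, charge, or hydrogen-bond donors and acceptors. The true size of the step remains unknown, because compound 1 gives only a limit: the limit of > 100000 nM in this assay, at which 1 of the 3 values shown sits.

Going by these compounds, whether bromo, methoxy or a nitrile at this position would give a lower or higher number remains open. So does whether the same swap would act alike in compound 2.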